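The source may report more compounds than this note shows. Statements on the series, on what has been measured and on what is new or still open speak of the compounds shown alone.

Compound 1 `Cc1cn(C2CCN(Cc3cccc(Oc4ccccc4)n3)CC2)c(=O)[nH]c1=O`: > 64000 nM
Compound 2 `Cc1ccc(Oc2cccc(CN3CCC(n4cc(C)c(=O)[nH]c4=O)CC3)c2)cc1`: > 64000 nM

Both results come from an ADME assay on MRC5 cells (Homo sapiens) for cytotoxicity, read by fluorescence and resazurin assay, with a stated time of 3 days; on this read-out lower numbers stand for stronger inhibition and higher numbers for weaker inhibition. Compound 1 gives > 64000 nM, which is a limit of the assay and not a number. Compound 2 gives > 64000 nM, which is also only a limit. Within the data shown here, compound 2 therefore stands with the only other measured compound at the limit of > 64000 nM in this assay, at which 2 of the 2 values shown sit. Among the measured compounds shown here, no exact value is available for either compound, and no step between measured compounds can be read.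

Compound 3 `Cc1cn(C2CCN(Cc3cccc(Oc4cccc(F)c4)c3)CC2)c(=O)[nH]c1=O` differs from compound 2 in one place: 3-fluorophenyl in place of 4-methylphenyl on an oxygen on an aromatic ring. In words, 3-fluorophenyl takes the place of 4-methylphenyl on an oxygen on an aromatic ring, while the rest of the structure stays the same.

The expected change a number no higher from compound 2 to compound 3 (the limit leaves the size open) in this assay is none beyond the usual scatter. This expectation rests on compound 2, which gives > 64000 nM, a limit. Another limit is the most likely result for compound 3. As a working figure, compound 3 is estimated at 64000 nM, with an expected range of 30000 nM to 100000 nM.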

Compound 3, half-maximal inhibitory concentration: > 64000 nM
Compound 3 ended at the assay's limit; the forecaster's own chance of this, stated with the estimate: 75%; the middle value lies on the limit itself.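

Among these compounds, compound 3 gives > 64000 nM in this assay, which is a limit and not a number, and compound 2 also has only a limit, so no step between compound 2 and compound 3 can be read. The compounds shown leave open whether 3-fluorophenyl and 4-methylphenyl differ at all in this read-out, since every result sits at one value: the limit of > 64000 nM in this assay, at which 3 of the 3 values shown sit.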